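Moving the methyl within the aryl group

The source may hold more compounds than are shown below. What is called first, only, known or untested is meant among the compounds shown, and "the series" means these compounds.

Compound 2 `COc1ccc(Cl)cc1S(=O)(=O)Nc1cncc(-c2ccccc2C)c1` gives 178 nM in an assay on isolated protein for inhibition of alkaline phosphatase, tissue-nonspecific isozyme (Homo sapiens); on this read-out lower numbers stand for stronger inhibition and higher numbers for weaker inhibition. Of the two compounds measured it holds the higher number, yet compound 1 `CNC(=O)c1cncc(NS(=O)(=O)c2cc(Cl)ccc2OC)c1` gives 109 nM, and the step of a 1.6-fold higher number from compound 1 to compound 2 (0.21 log units; within the scatter) keeps the two together. Compound 3 `COc1ccc(Cl)cc1S(=O)(=O)Nc1cncc(-c2ccc(C)cc2)c1` differs from compound 2 by 4-methylphenyl in place of 2-methylphenyl on an aromatic carbon. Among the compounds with values here, the single measured step swaps in a different group entirely, so nothing measured speaks to moving the methyl within the same group. Compound 3 is therefore expected to stay close to compound 2, with the estimated step of a 1.0-fold higher number from compound 2 to compound 3 (0.00 log units; within the scatter) lying within the scatter. The estimate for compound 3 is 180 nM, expected between 60 nM and 540 nM.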

Compound 3, half-maximal inhibitory concentration: 147 nM
For compound 3 the middle estimate is 1.2-fold (0.09 log units) above the measured one, within the range that was stated.
By their numbers in this assay, from the lowest: compounds 1, 3 and 2 (each within the scatter of the next).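

Here the placement of the methyl on the phenyl ring is tested directly: 4-methylphenyl in place of 2-methylphenyl gives a 1.2-fold lower number from compound 2 to compound 3 (0.08 log units; within the scatter) in this assay, so these two placements cannot be told apart. Against methylcarbamoyl at the same place, 4-methylphenyl gives a 1.3-fold higher number from compound 1 to compound 3 (0.13 log units; within the scatter), so all three groups read alike here. Nothing available bears on why these numbers sit so close. Still open, on these data alone, is whether an amine or a carboxylic acid on the phenyl ring, or a longer chain in place of the methyl, would separate the numbers.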